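Swapping Fluoro for Methyl on the Sulfonyl Aryl Ring

This account rests on a few compounds, and the source may have more. Where it says the series, first, only, none or still open, it means among the compounds named here.

Compound 1 `COc1ccc(S(=O)(=O)c2cnc3ccc(F)cc3c2N2CCC(C)CC2)cc1` gives 85%.
Compound 2 `Cc1ccc2ncc(S(=O)(=O)c3ccc(C#N)cc3)c(N3CCC(C)CC3)c2c1` gives 55%.
Compound 3 `CC1CCN(c2c(S(=O)(=O)c3ccc(F)cc3)cnc3c(F)cccc23)CC1` gives 26%.

All three were tested in an assay on isolated protein for displacement of a labelled ligand from metabotropic glutamate receptor 5 (Homo sapiens), with a stated time of 60 min, tested at 1 uM; on this read-out higher numbers stand for more inhibition at the one concentration tested (going by the name of the read-out) and lower numbers for less inhibition. Among the three, compound 3 stands lowest: its number lies well below that of compound 2 and further still below that of compound 1, both gaps lying beyond the usual scatter of this kind of measurement. The three compounds share a core but differ in more than one place at once, so no single change can be read from those gaps.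

Compound 4 `Cc1ccc(S(=O)(=O)c2cnc3c(F)cccc3c2N2CCC(C)CC2)cc1` has not yet been measured. It differs from compound 3 in one place only: methyl in place of fluoro on an aromatic carbon. Among the compounds with values here, both groups are single heavy atoms without donors or acceptors, and no other measured pair shows this same swap, so there is no direct guide to its effect. A small shift in either direction, or none beyond the scatter, seems the most reasonable expectation in this assay. The step of a number 9 percentage points higher from compound 3 to compound 4 (within the scatter) is therefore estimated to be small and upward. Compound 4 is expected to give about 35%, most likely between 15% and 60%.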

Compound 4, a percentage reported as inhibition, at one concentration (the size of the read-out at that concentration, not a potency): 93%
Beside the measured number, compound 4's estimate is 58 percentage points below it; the measured number lies above the stated range.
By their numbers in this assay, from the lowest: compound 3; then compound 2; then compounds 1 and 4 (each within the scatter of the next).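

Putting methyl in place of fluoro on an aromatic carbon, para to a large group, gives a number 67 percentage points higher from compound 3 to compound 4 (beyond the scatter) in this assay. The earlier compounds shown here differed from one another in more than one place, so they could not tie a change in the number to any single spot; this pair can, and it shows that the group at this position has a strong bearing on the read-out, even though the two groups match in heavy-atom count and neither has hydrogen-bond donors or acceptors. Nothing shown here indicates what lies behind a step of this size from so small a swap.

As far as these compounds go, this is a single pair on a single core, tested at one concentration, so it remains open whether the same swap would have a comparable effect on compounds that differ elsewhere, such as those with the other substitution patterns on the core, or how it would look as a true potency. From the compounds shown here alone, it also remains open how a chloro group, an ethyl chain or an amine at this position would compare with the methyl of compound 4, at 93%.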